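From compound 3 to compound 4: 3-cyanophenyl enters

The source may report more compounds than this note shows. Statements on the series, on what has been measured and on what is new or still open speak of the compounds shown alone.

compound 1 `COc1ccc([C@H]2CC(=O)N(c3cccc(O)c3)C2)cc1OC1CCCC1`: > 10000 nM
compound 2 `COc1ccc([C@H]2CC(=O)N(c3cc(N)cc(N)c3)C2)cc1OC1CCCC1`: > 10000 nM
compound 3 `COc1ccc([C@H]2CC(=O)N(c3cccc(N)c3C)C2)cc1OC1CCCC1`: > 10000 nM

In a functional assay on HEK293 cells (Homo sapiens) for cytotoxicity (a lower number here means that less compound is tolerated, a higher number that more compound is tolerated), compound 3 gives > 10000 nM as a limit of the assay, not a number. The series shows the limit of > 10000 nM in this assay, at which 3 of the 3 values shown sit, and no other kind of result.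

Compound 4 `COc1ccc([C@H]2CC(=O)N(c3cccc(C#N)c3)C2)cc1OC1CCCC1` carries 3-cyanophenyl in place of 3-amino-2-methylphenyl on an amide-type nitrogen in a ring, a change counted as 3-cyanophenyl in place of 3-amino-2-methylphenyl on an amide-type nitrogen in a ring on the shared core.

Within the data shown here, three measured steps bear on this change: a step that the two limits leave unreadable from compound 1 to compound 2 and a step that the two limits leave unreadable from compound 1 to compound 3 and a step that the two limits leave unreadable from compound 2 to compound 3 all exchange the group on that nitrogen, and none has a readable size. They give no direction, so no step beyond the scatter is expected in this assay here. The expected result is a step that the limit leaves unreadable from compound 3 to compound 4 with neither direction favoured. Compound 4 is expected most probably to be reported at the same limit. The estimate for compound 4 is 12000 nM within an estimated range from 5000 nM to 30000 nM.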

Compound 4, half-maximal cytotoxic concentration: > 10000 nM
Compound 4 gave a limit, no number (the forecaster's own chance of this, stated with the estimate: 88%); the middle value is on the limit's open side.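

In this assay compound 4 gives > 10000 nM as a limit and not a number. Among these compounds, no step from compound 1, compound 2 or compound 3 to compound 4 can be read. The compounds shown leave open whether any of these groups on the amide-type nitrogen differs from another in cytotoxicity.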